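Back from a dichlorinated ring to a single-chlorine diazine

This account rests on a few compounds, and the source may have more. Where it says the series, first, only, none or still open, it means among the compounds named here.

Measured so far:
Compound 1, `O=C(Nc1cc(C(F)(F)F)cc(C(F)(F)F)c1)c1cnc(Cl)nc1`: 300 nM
Compound 2, `O=C(Nc1cc(C(F)(F)F)cc(C(F)(F)F)c1)c1ccc(Cl)nn1`: 1700 nM
Compound 3, `O=C(Nc1cc(C(F)(F)F)cc(C(F)(F)F)c1)c1cc(Cl)nc(Cl)n1`: > 10000 nM (a limit, not a number)

All three compounds share the same amide and the same aryl portion; they differ only in the chlorinated heteroaromatic ring on the carbonyl carbon. In an assay on Jurkat cells for activation of nuclear factor NF-kappa-B complex (Homo sapiens) (a lower number here means a stronger inhibitor, a higher number a weaker inhibitor), compound 1 gives 300 nM, and compound 2 gives 1700 nM, a step of a 5.7-fold higher number from compound 1 to compound 2 (0.75 log units; beyond the scatter). For compound 3 this assay reports only a limit, > 10000 nM, so its true value is not known; it sits at the limit of > 10000 nM in this assay, at which 1 of the 3 values shown sits. Compound 3 is therefore the weakest of the three by at least an at least 33-fold higher number from compound 1 to compound 3 (1.52 log units; beyond the scatter) and an at least 5.8-fold higher number from compound 2 to compound 3 (0.76 log units; beyond the scatter).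

Compound 4, `O=C(Nc1cc(C(F)(F)F)cc(C(F)(F)F)c1)c1cnc(Cl)cn1`, has not been measured. The change is 5-chloropyrazin-2-yl in place of 2,6-dichloropyrimidin-4-yl on a carbonyl carbon. This moves away from the ring that gave the weakest result and toward a chloro-diazine of the kind carried by compound 1 and compound 2. Both measured steps to the dichlorinated ring were large or at least modest, so the reverse direction is expected here: a clearly lower number in this assay, likely landing near the values of compound 1 and compound 2. For compound 4 the expected result is 800 nM, between 200 nM and 3500 nM, an expected step of an at least 12-fold lower number from compound 3 to compound 4 (1.09 log units; beyond the scatter).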

Compound 4, half-maximal inhibitory concentration: 4000 nM
Estimate against measurement, compound 4: 5.0-fold (0.70 log units) below; the measured number lies above the stated range.
By their numbers in this assay, from the lowest: compound 1; then compound 2; then compound 4. At a limit, above all of these: compound 3.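

Returning to a ring with one chlorine recovers activity only in part: in this assay the change gives an at least 2.5-fold lower number from compound 3 to compound 4 (0.39 log units; beyond the scatter). The three single-chlorine rings are also not interchangeable, since holding the chlorine count at one still leaves a 2.4-fold higher number from compound 2 to compound 4 (0.37 log units; beyond the scatter) and a 13-fold higher number from compound 1 to compound 4 (1.12 log units; beyond the scatter), so carrying one chlorine on a diazine is not enough to match compound 1. The step from compound 3 gives only a minimum size, as the value for compound 3 is a limit and not a number: the limit of > 10000 nM in this assay, at which 1 of the 4 values shown sits.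

Why these rings differ cannot be told from these values. Going by these compounds, it also remains open whether the chlorine itself is needed, for example how compound 1 would respond if an amine or a methoxy group took the place of its chlorine on the 2-chloropyrimidin-5-yl ring.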